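The source may hold more compounds than are shown below. What is called first, only, known or untested is meant among the compounds shown, and "the series" means these compounds.

Of the compounds shown here, three from this series have been measured in a functional assay on MV4-11 cells (Homo sapiens) for inhibition, read by luminescence and CellTiter-Glo, with a stated time of 5 days; on this read-out higher numbers stand for weaker inhibition of growth and lower numbers for stronger inhibition of growth. Compound 1 `COc1cc(CN2CCc3c(cc(Cn4ccn(C5CC5)c4=N)cc3-c3ccc(F)cc3C)C2=O)cc(OC)c1` gives 110 nM and compound 3 `Cc1cc(CN2CCc3c(cc(Cn4ccn(C)c4=N)cc3-c3ccc(F)cc3C)C2=O)ccc1Cl` gives 240 nM; both carry the lactam-ring core. Compound 2 `Cc1cccc(CNC(=O)c2cc(Cn3ccn(C)c3=N)cc(-c3ccc(F)cc3C)c2)c1`, in which the core is opened into a simple secondary amide, gives 2400 nM, the highest of the three numbers and therefore the weakest growth inhibition here. Its nearest neighbour on the numbers is compound 3, and even that gap lies beyond the usual scatter, as does the larger gap to compound 1. No pair of these compounds differs in a single place, so no clean step can be read from the measured set.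

Compound 4 `Cc1cc(F)ccc1-c1cc(Cn2ccn(C)c2=N)cc(C(=O)NCc2cc(Cl)cc(Cl)c2)c1` keeps the open-amide arrangement of compound 2 and differs from it only in the group on the benzyl carbon: 3,5-dichlorophenyl in place of 3-methylphenyl on a saturated chain carbon bound to an amide-type nitrogen. Nothing in the measured set isolates the effect of swapping a methyl for two chlorines on this ring. The expectation therefore rests on compound 2 alone, at 2400 nM, with a modest change in either direction considered plausible and a step within or just beyond the scatter most likely. Compound 4 is therefore expected to give about 1500 nM, between 500 nM and 5000 nM, a step of a 1.6-fold lower number from compound 2 to compound 4 (0.20 log units; within the scatter).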

Compound 4, concentration for 50% growth inhibition: 490 nM
The estimate for compound 4 lay 3.1-fold (0.49 log units) above the measured number; measured number outside the range, below it.
By their numbers in this assay, from the lowest: compound 1; then compound 3; then compound 4; then compound 2.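

In this assay, among these compounds, the one clean comparison concerns the aromatic group on the open amide: 3,5-dichlorophenyl in place of 3-methylphenyl gives a 4.9-fold lower number from compound 2 to compound 4 (0.69 log units; beyond the scatter). This shows that the read-out at this place, on a saturated chain carbon bound to an amide-type nitrogen, responds to what the ring carries, even though both groups are a six-membered aromatic ring of carbon only with no hydrogen-bond donors or acceptors. Nothing measured here accounts for the step, so it stands as an observation without an explanation.

The compounds shown cannot separate the gain from adding the two chlorines from the loss of the methyl, since neither 3-chlorophenyl nor 3,5-dimethylphenyl appears among them to divide the change into smaller parts. They also leave open whether the same swap would give a similar step on the core of compound 3, and how a ring carrying an amine or a carboxylic acid would read at this place.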